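A few compounds are considered here, and "the series" means these few. Any claim that something is new, unique, unknown or untested is made for them only; others in the source may bear on it.

Three compounds from this series share one core and differ only in the aromatic ring attached to the carbonyl carbon of an amide. Compound 1 `COc1cc(N(C)C)c(NC(=O)c2ccncc2)cc1Nc1nccc(-c2cn(C)c3ccccc23)n1` carries pyridin-4-yl there; in a functional assay on A549 cells (Homo sapiens) for antiproliferative activity, read by MTT assay, with a stated time of 72 h (on this read-out lower numbers stand for stronger inhibition and higher numbers for weaker inhibition), compound 1 gives 9000 nM. Compound 2 `COc1cc(N(C)C)c(NC(=O)c2ccnc(Cl)c2)cc1Nc1nccc(-c2cn(C)c3ccccc23)n1` carries 2-chloropyridin-4-yl, and in this assay compound 2 gives 3430 nM, a change of a 2.6-fold lower number from compound 1 to compound 2 (0.42 log units; beyond the scatter). Compound 3 `COc1cc(N(C)C)c(NC(=O)c2ccncn2)cc1Nc1nccc(-c2cn(C)c3ccccc23)n1` carries pyrimidin-4-yl, and in this assay compound 3 gives 5160 nM. The move a 1.7-fold lower number from compound 1 to compound 3 (0.24 log units; within the scatter) and the move a 1.5-fold higher number from compound 2 to compound 3 (0.18 log units; within the scatter) both stay inside the usual scatter, so compound 3 sits second highest of the three numbers, within the scatter of compound 2 and of compound 1 alike.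

Compound 4 `COc1cc(N(C)C)c(NC(=O)c2ncccn2)cc1Nc1nccc(-c2cn(C)c3ccccc23)n1` changes only the ring on the carbonyl carbon: pyrimidin-2-yl in place of pyrimidin-4-yl on a carbonyl carbon. The two measured ring swaps at this same position, from compound 1 to compound 3 and from compound 2 to compound 3, each stayed within the scatter, and nothing in the data suggests that rearranging the same atoms into pyrimidin-2-yl should behave differently. The expected step of a 1.0-fold lower number from compound 3 to compound 4 (0.01 log units; within the scatter) is therefore none beyond the scatter. Compound 4 is estimated at 5000 nM in this assay, with a range from 2500 nM to 10000 nM.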

Compound 4, half-maximal inhibitory concentration: 8640 nM
Compound 4: the middle estimate sits 1.7-fold (0.24 log units) below what was measured; measured number inside the range.
By their numbers in this assay, from the lowest: compounds 2, 3, 4 and 1 (each within the scatter of the next, the first and the last beyond it).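

In this assay, rearranging the same ring atoms on the carbonyl carbon, pyrimidin-2-yl in place of pyrimidin-4-yl, gives a step within the scatter (a 1.7-fold higher number from compound 3 to compound 4 (0.22 log units; within the scatter)), and pyrimidin-2-yl also stays within the scatter of pyridin-4-yl (a 1.0-fold lower number from compound 1 to compound 4 (0.02 log units; within the scatter)). The new compound does add a modest contrast beyond the scatter with the chlorinated ring (a 2.5-fold higher number from compound 2 to compound 4 (0.40 log units; beyond the scatter)), so 2-chloropyridin-4-yl now stands apart from pyridin-4-yl and pyrimidin-2-yl, though compound 3 remains within its scatter. No measurement here offers a reason for any of these steps.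

Going by these compounds, whether a chloro group on a pyrimidine ring would shift the number as it does on pyridin-4-yl remains open. Also open, on these data alone, is how this position would respond to a non-aromatic ring such as morpholine, or to an aminomethyl group on the pyridine ring.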